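The source may report more compounds than this note shows. Statements on the series, on what has been measured and on what is new or still open speak of the compounds shown alone.

Compound 1 `Cc1oc2ncnc(Nc3cccc(Br)c3)c2c1C(=O)O` gives 43000 nM in a functional assay on A549 cells (Homo sapiens) for cytotoxicity, read by MTT assay, with a stated time of 72 h; a lower number here means a stronger inhibitor, a higher number a weaker inhibitor. Compound 2 `CCOC(=O)c1c(C)oc2ncnc(Nc3ccc(OCc4cccc(F)c4)c(Cl)c3)c12` gives 500 nM in this assay. Compound 3 `CCOC(=O)c1c(C)oc2ncnc(Nc3cccc(Br)c3)c12` gives only a limit in this assay, > 1000000 nM.

Compound 1 and compound 3 share a core and differ by hydrogen in place of ethyl on an oxygen next to a carbonyl group. That change brings an at least 23-fold lower number from compound 3 to compound 1 (1.36 log units; beyond the scatter); its size rests on the limit at which compound 3 sits (the limit of > 1000000 nM in this assay, at which 1 of the 3 values shown sits). Compound 2 holds the lowest number among the two measured ones. The difference between the cores of compound 2 and compound 3 is not broken down here.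

Compound 4 `Cc1oc2ncnc(Nc3ccc(OCc4cccc(F)c4)c(Cl)c3)c2c1C(=O)O` is not yet measured. It differs from compound 2 by hydrogen in place of ethyl on an oxygen next to a carbonyl group, the same change, at the same place, as that from compound 3 to compound 1. A lower number is therefore expected for compound 4, with a step of a 3.3-fold lower number from compound 2 to compound 4 (0.52 log units; beyond the scatter), smaller than the earlier one because an at least 23-fold lower number from compound 3 to compound 1 (1.36 log units; beyond the scatter) is only a lower bound set by the limit (the limit of > 1000000 nM in this assay, at which 1 of the 3 values shown sits). Compound 4 is estimated at 150 nM, expected between 30 nM and 1500 nM.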

Compound 4, half-maximal inhibitory concentration: 21400 nM
Beside the measured number, compound 4's estimate is 140-fold (2.15 log units) below it, and the stated range ends below it.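

In this assay, the change from ethoxycarbonyl to carboxy brings a 43-fold higher number from compound 2 to compound 4 (1.63 log units; beyond the scatter), so the step runs opposite to the one seen on the other core, and the two do not match: the same change on two cores in this assay, an at least 23-fold lower number (1.36 log units; beyond the scatter) from compound 3 to compound 1 and a 43-fold higher number (1.63 log units; beyond the scatter) from compound 2 to compound 4, at least 990-fold (2.99 log units) apart, beyond the scatter of two such steps. The earlier step gives only a bound, since compound 3 stands at a limit: the limit of > 1000000 nM in this assay, at which 1 of the 4 values shown sits. These two pairs show that the result of this change depends on the core, but they give no rule for any other core.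

On these data alone, whether a methyl ester or an amide in place of the ethyl ester would behave the same way on each core stays open. Also open, as far as these compounds go, is which part of the difference between the cores of compound 2 and compound 3 reverses the step.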